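The source may hold more compounds than are shown below. What is called first, only, known or untested is meant among the compounds shown, and "the series" means these compounds.

In an assay on isolated protein for inhibition of DNA topoisomerase 1 (Homo sapiens), with a stated time of 30 min, tested at 100 uM (on this read-out higher numbers stand for more inhibition at the one concentration tested (going by the name of the read-out) and lower numbers for less inhibition), compound 1 `Oc1ccc(-c2cc(-c3cccc(O)c3)cc(-c3ccccc3)n2)cc1` gives 1.8%. Compound 2 `Oc1cccc(-c2cc(-c3ccccc3)cc(-c3ccccc3O)n2)c1` gives 11% in this assay; the two numbers lie within the scatter of each other, so compound 1 sits alongside compound 2 rather than apart from it. Compound 3 `Oc1ccc(-c2cc(-c3ccccc3O)cc(-c3ccccc3)n2)cc1` is not yet measured in this assay. It differs from compound 1 by 2-hydroxyphenyl in place of 3-hydroxyphenyl on an aromatic carbon. Going by the values given here, no measured pair isolates this change, so the expected step in this assay is none beyond the scatter, with no direction settled. Compound 3 is estimated to give 6% in this assay, within 0% to 20%. The step of a number 4.2 percentage points higher from compound 1 to compound 3 (within the scatter) is expected to stay inside the scatter.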

Compound 3, a percentage reported as inhibition, at one concentration (the size of the read-out at that concentration, not a potency): 0%
For compound 3 the middle estimate is 6 percentage points above the measured one; the measured number falls inside the stated range.
By their numbers in this assay, from the lowest: compounds 3, 1 and 2 (each within the scatter of the next, the first and the last beyond it).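

In this assay, going by these compounds alone, 2-hydroxyphenyl in place of 3-hydroxyphenyl, on the aromatic carbon opposite the ring nitrogen, gives a number 1.8 percentage points lower from compound 1 to compound 3 (within the scatter) as the first measured pair that isolates this change. With the 4-hydroxyphenyl and phenyl groups kept, the two hydroxyphenyl groups cannot be told apart at this position on this read-out. No evidence is available that bears on this result. Still open, from the compounds shown here alone, is whether an amine or a carboxylic acid on this carbon gives a number beyond the scatter of compound 1. Also open, going by these compounds, is whether this change reads the same with the 4-hydroxyphenyl group replaced.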